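The source may hold more compounds than are shown below. What is called first, only, known or untested is meant among the compounds shown, and "the series" means these compounds.

Working notes on the series.

In a functional assay on A549 cells (Homo sapiens) for antiproliferative activity, read by MTT assay (on this read-out higher numbers stand for weaker inhibition and lower numbers for stronger inhibition), compound 1 `COc1cc2c(Oc3ccc(NC(=O)Nc4cccc(C)c4)cc3)ccnc2cc1OCCCCCCC(=O)NO` gives 2010 nM. Of the three numbers in hand it stands second highest: compound 2 `COc1cc2c(Oc3ccc(NC(=O)Nc4ccc(C(F)(F)F)cc4Cl)cc3)ccnc2cc1OCCCCCCC(=O)NO` gives 970 nM, and compound 3 `COc1cc2c(Oc3ccc(NC(=O)Nc4ccc(Cl)c(C(F)(F)F)c4)cc3)ccnc2cc1OCCCCCCC(=O)NO` gives 5020 nM. The two measured steps from compound 1 both vary the group on the amide-type nitrogen and run in opposite directions: a 2.1-fold lower number from compound 1 to compound 2 (0.32 log units; beyond the scatter), whereas a 2.5-fold higher number from compound 1 to compound 3 (0.40 log units; beyond the scatter). Between the two substituted phenyl groups the gap is larger, a 5.2-fold higher number from compound 2 to compound 3 (0.71 log units; beyond the scatter).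

Compound 4 `COc1cc2c(Oc3ccc(NC(=O)N/N=C/c4ccccc4F)cc3)ccnc2cc1OCCCCCCC(=O)NO` differs from compound 1 at the same place, (a group of 9 heavy atoms (7 carbon, 1 nitrogen, 1 fluorine; one six-membered aromatic ring of carbon only) in place of a group of 7 heavy atoms (7 carbon; one six-membered aromatic ring of carbon only), on an amide-type nitrogen). Going by the values given here, no measured step matches this change, since every measured group on this nitrogen is a substituted phenyl while the entering group carries a double bond outside the aromatic ring and one hydrogen-bond acceptor. Among the compounds with values here, what the measured steps show is that changes at this nitrogen have moved the number modestly either way, by no more than the step from compound 2 to compound 3. The expectation is therefore a modest step at most, with the direction undecided, so a 1.2-fold higher number from compound 1 to compound 4 (0.09 log units; within the scatter) is taken as near zero with a wide band. In this assay compound 4 is estimated at 2500 nM, expected between 700 nM and 9000 nM.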

Compound 4, half-maximal inhibitory concentration: 7780 nM
Compound 4: middle estimate off by 3.1-fold (0.49 log units), on the low side; measured number inside the range.
By their numbers in this assay, from the lowest: compound 2; then compound 1; then compounds 3 and 4 (each within the scatter of the next).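

In this assay, going by these compounds alone, the first group on this amide-type nitrogen with a double bond outside aromatic rings does not bring the number down: a 3.9-fold higher number from compound 1 to compound 4 (0.59 log units; beyond the scatter), the step runs the same way as the one to the 4-chloro-3-(trifluoromethyl)phenyl group of compound 3. The two groups cannot be separated, with a 1.5-fold higher number from compound 3 to compound 4 (0.19 log units; within the scatter), although they differ in atom count and in hydrogen-bond acceptors, so a group quite unlike a substituted phenyl can read like one at this place. Within the data shown here, the range at this nitrogen also widens, with an 8.0-fold higher number from compound 2 to compound 4 (0.90 log units; beyond the scatter), leaving the 2-chloro-4-(trifluoromethyl)phenyl group of compound 2 as the only one with a number below that of compound 1, and nothing available accounts for these differences.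

From the compounds shown here alone, the entering group differs from 3-methylphenyl in its nitrogen, its fluorine and its double bond together, so which of these goes with the step stays open. Also open, going by these compounds, is where an amine or a carboxylic acid on this nitrogen would fall, and whether the order of these groups would hold with a shorter chain elsewhere on the core.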